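The source may report more compounds than this note shows. Statements on the series, on what has been measured and on what is new or still open speak of the compounds shown alone.

Measured so far in a functional assay on A549 cells (Homo sapiens) for cytotoxicity, read by MTT assay, with a stated time of 24 h, tested at 40 uM; a lower number here means a stronger effect, a higher number a weaker effect of the compound at the concentration tested:
- compound 1 `CCCOC(=O)CCC(=O)N1CCN(CCCOc2cc3c(Nc4ccc(F)c(Cl)c4)ncnc3cc2OC)CC1`: 80.9%
- compound 2 `CCCCCCCCCOC(=O)CCC(=O)N1CCN(CCCOc2cc3c(Nc4ccc(F)c(Cl)c4)ncnc3cc2OC)CC1`: 17.9%

Compound 2 stands lowest of the two numbers shown; its nearest neighbour is compound 1, whose number is higher by a step that lies beyond the scatter. That single measured step, a number 63 percentage points lower from compound 1 to compound 2 (beyond the scatter), is the only one available, and it bears directly on the change at hand, since it lengthened the same ester chain.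

Compound 3 `CCCCCCCCCCCCOC(=O)CCC(=O)N1CCN(CCCOc2cc3c(Nc4ccc(F)c(Cl)c4)ncnc3cc2OC)CC1` is not yet measured. It differs from compound 2 in one place: propyl in place of hydrogen on a saturated chain carbon, nine bonds along the chain from an oxygen next to a carbonyl group.

The earlier lengthening of this chain, from compound 1 to compound 2, produced a large fall in this assay. A further lengthening of the same chain is therefore expected to move the number in the same downward direction or to leave it near where compound 2 stands; because 17.9% is already low, there is little room for a fall as large as before. For compound 3 the expected step is a number 5.9 percentage points lower from compound 2 to compound 3 (within the scatter). Compound 3 is thus estimated at 12%, with a range from 2% to 28%.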

Compound 3, a percentage reported as activity, at one concentration (the size of the read-out at that concentration, not a potency): 5.7%
Beside the measured number, compound 3's estimate is 6.3 percentage points above it; the range from low to high includes it.
By their numbers in this assay, from the lowest: compound 3; then compound 2; then compound 1.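

In this assay, the ester chain keeps mattering beyond the length reached in compound 2: adding propyl at the position nine bonds along the chain from the oxygen gives a number 12.2 percentage points lower from compound 2 to compound 3 (beyond the scatter), so the fall did not stop there, although this step is modest where the earlier one was large. Taken as a single change, the nonyl addition gives a number 75.2 percentage points lower from compound 1 to compound 3 (beyond the scatter), and among these three compounds the number falls as the chain grows, with none going against that order. Nothing available here shows what lies behind this fall.

Among the compounds shown here, a chain longer than the one in compound 3 could lower the number further or leave it level, and these three compounds cannot tell which. They also leave open how a chain ending in an amine or a carboxylic acid would read, and, since each compound has a value at only one concentration, how the compounds compare in potency.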